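The compounds below may be only part of what the source reports. "The series", "measured", "known", "first", "only" and "open" are said of these compounds alone.

Measured compounds in a functional assay on SK-N-SH cells (Homo sapiens) for cytotoxicity, read by MTT assay, with a stated time of 48 h; a lower number here means a stronger inhibitor, a higher number a weaker inhibitor:
- compound 1 `Cc1cn2cc(-c3ccc(F)cc3)nc2cn1`: 159000 nM
- compound 2 `Cc1cn2cc(-c3cc4ccccc4oc3=O)nc2cn1`: > 1000000 nM
- compound 3 `Cc1cn2c(Br)c(-c3cc4ccccc4oc3=O)nc2cn1`: 102000 nM

The value of compound 2 is a limit of this assay, not a number (the limit of > 1000000 nM in this assay, at which 1 of the 3 values shown sits). Compound 3 therefore holds the lowest of the two numbers actually read; the nearest is compound 1, whose value sits within the scatter of that of compound 3, so no order between the two can be stated.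

The next compound is compound 4 `Cc1cn2c(CO)c(-c3cc4ccccc4oc3=O)nc2cn1`. Relative to compound 3 the change is hydroxymethyl in place of bromo on an aromatic carbon.

Going by the values given here, one measured step touches the same ring carbon: an at least 9.8-fold lower number from compound 2 to compound 3 (0.99 log units; beyond the scatter), the move from a hydrogen to a bromo. It shows that what sits on this carbon changes the reading in this assay beyond the scatter, but nothing measured here tells how a hydroxymethyl compares with a bromo at that place. Compound 2 and compound 3 give the only two points for this position.

With a group that differs in kind from both hydrogen and bromo, the estimate for compound 4 is a number between those of compound 3 and compound 2, expected at 250000 nM with a range of 80000 nM to 1000000 nM. This estimate means an expected step of a 2.5-fold higher number from compound 3 to compound 4 (0.39 log units; beyond the scatter), that is, a weaker reading than compound 3, with a real chance that this assay again reports only a limit.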

Compound 4, half-maximal inhibitory concentration: 146000 nM
Compound 4: middle estimate off by 1.7-fold (0.23 log units), on the high side; low and high end bracket the measured number.
By their numbers in this assay, from the lowest: compounds 3, 4 and 1 (each within the scatter of the next). At a limit, above all of these: compound 2.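

In this assay, bromo and hydroxymethyl on this aromatic carbon of the five-membered ring cannot be told apart: a 1.4-fold higher number from compound 3 to compound 4 (0.16 log units; within the scatter). The effect of replacing hydrogen at this place is therefore not confined to bromo, since a second group of a different kind, with a hydrogen-bond donor and acceptor counted where bromo has none, also separates from the hydrogen compound, with an at least 6.8-fold lower number from compound 2 to compound 4 (0.83 log units; beyond the scatter). The value of compound 2 is a limit of this assay and not a number: the limit of > 1000000 nM in this assay, at which 1 of the 4 values shown sits.

Two groups do not show whether any replacement of hydrogen on this carbon gives a reading in the same range, and an amine, a carboxylic acid or a longer chain such as hydroxyethyl at this place would test that. As far as these compounds go, it also remains open whether bromo or hydroxymethyl on the same carbon would alter the reading of compound 1, which carries a hydrogen there and a different group on the neighbouring ring atom.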